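The compounds below may be only part of what the source reports. "The series", "measured", "known", "first", "only" and "open" are said of these compounds alone.

Measured compounds:
compound 1, `Nc1ccc(Nc2c(C(=O)NCc3ccc(F)cc3)nc(Br)c3cccnc23)cc1` — 7000 nM
compound 2, `N[C@H]1CC[C@H](Nc2c(C(=O)NCc3cccc(C(F)(F)F)c3)nc(Br)c3cccnc23)CC1` — 4200 nM

In a functional assay on MDA-MB-435 cells (Homo sapiens) for cytotoxicity, read by MTT assay, with a stated time of 72 h (on this read-out higher numbers stand for weaker inhibition and lower numbers for stronger inhibition), compound 1 gives 7000 nM, the larger of the two numbers shown; compound 2 gives 4200 nM, and the gap between the two lies within the scatter, so no rank between them is drawn. Compound 2 also differs from compound 1 in more than one place, so nothing measured speaks to a single change.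

Compound 3 `NCCCNc1c(C(=O)NCc2ccc(F)cc2)nc(Br)c2cccnc12` differs from compound 1 in one place: 3-aminopropyl in place of 4-aminophenyl on a nitrogen on an aromatic ring. Among the compounds with values here, no measured pair carries a change of this kind, so there is no step to lean on. The step from compound 1 to compound 3 is therefore expected to stay inside the scatter, with no direction favoured: no change at the digits printed from compound 1 to compound 3 (within the scatter). Compound 3 is expected to give about 7000 nM in this assay, within a range from 2500 nM to 20000 nM.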

Compound 3, half-maximal inhibitory concentration: 5000 nM
The estimate for compound 3 lay 1.4-fold (0.15 log units) above the measured number, within the range that was stated.
By their numbers in this assay, from the lowest: compounds 2, 3 and 1 (each within the scatter of the next).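

The series now has its first single-place step at this position: in this assay, 3-aminopropyl in place of 4-aminophenyl on a nitrogen on an aromatic ring gives a small shift (a 1.4-fold lower number from compound 1 to compound 3 (0.15 log units; within the scatter)). For this pair, the six-membered aromatic ring of 4-aminophenyl can give way to an open chain with no ring without taking the number beyond the scatter, while the count of hydrogen-bond donors and acceptors in the group stays the same. Nothing available explains this result.

From the compounds shown here alone, it remains open whether a longer chain, or a hydroxyl or carboxylic acid in place of the terminal amine, would move the number beyond the scatter. Going by these compounds, it is also open whether the same swap would give a similar step with a 3-(trifluoromethyl)benzyl group on the amide.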